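This account rests on a few compounds, and the source may have more. Where it says the series, first, only, none or still open, it means among the compounds named here.

In an assay on isolated protein with malate dehydrogenase, cytoplasmic (Sus scrofa) as the target (on this read-out higher numbers stand for weaker inhibition and lower numbers for stronger inhibition), the measured compounds stand as follows:

compound 1 `CN(C)c1ccc2c(O)c(C(=O)O)cnc2c1`: 372000 nM
compound 2 `O=C(O)c1cnc2cc(O)ccc2c1O`: 955000 nM
compound 3 `CC(=O)c1ccc2c(O)c(C(=O)O)cnc2c1`: 912000 nM

Compound 3 holds the second highest of the three numbers. Among the measured compounds shown here, its nearest neighbour is compound 2, whose value sits within the scatter of it; the only step beyond the scatter on this side of the series is a 2.5-fold higher number from compound 1 to compound 3 (0.39 log units; beyond the scatter), while a 1.0-fold lower number from compound 2 to compound 3 (0.02 log units; within the scatter) stays within it.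

Compound 4 `NS(=O)(=O)c1ccc2c(O)c(C(=O)O)cnc2c1` differs from compound 3 in one place: sulfamoyl in place of acetyl on an aromatic carbon. For the measured compounds named here, no measured step brings sulfamoyl into this position. The two steps that touch the same aromatic carbon are a 1.0-fold lower number from compound 2 to compound 3 (0.02 log units; within the scatter) and a 2.5-fold higher number from compound 1 to compound 3 (0.39 log units; beyond the scatter); exchanging acetyl for hydroxy leaves the number where it is, and only dimethylamino gives a lower one. With nothing to point either way, the expected step for compound 4 is a 1.0-fold lower number from compound 3 to compound 4 (0.01 log units; within the scatter), that is, none beyond the scatter. Compound 4 is therefore estimated at 900000 nM, with a range of 400000 nM to 2000000 nM.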

Compound 4, half-maximal inhibitory concentration: 692000 nM
The estimate for compound 4 lay 1.3-fold (0.11 log units) above the measured number; the measured number falls inside the stated range.
By their numbers in this assay, from the lowest: compounds 1, 4, 3 and 2 (each within the scatter of the next, the first and the last beyond it).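

In this assay, sulfamoyl on this aromatic carbon stays within the scatter of all three earlier groups (a 1.3-fold lower number from compound 3 to compound 4 (0.12 log units; within the scatter); a 1.4-fold lower number from compound 2 to compound 4 (0.14 log units; within the scatter); a 1.9-fold higher number from compound 1 to compound 4 (0.27 log units; within the scatter)). Among the compounds shown here, the position therefore accepts a group with more heavy atoms and hydrogen-bond acceptors than acetyl without a step beyond the scatter, and compound 4 is the first compound within the scatter of compound 1 as well as of compound 2 and compound 3, while compound 1 remains beyond the scatter of those two. Nothing available explains these small differences.

As far as these compounds go, whether dimethylamino's modest separation from hydroxy and acetyl extends to a primary amine or a longer dialkylamino chain remains open. So does whether a halogen such as chlorine on this carbon would give a step beyond the scatter of all four compounds.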